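The source may hold more compounds than are shown below. What is called first, only, known or untested is meant among the compounds shown, and "the series" means these compounds.

The measured compounds:

Compound 1, `CN(C)CCCCn1c(N)c(-c2nc3ccccc3n2C)c2nc(C#N)c(C#N)nc21`, gives 3870 nM in an ADME assay on HEK293 cells (Homo sapiens) for cytotoxicity, read by MTT assay, with a stated time of 48 h; on this read-out lower numbers stand for stronger inhibition and higher numbers for weaker inhibition.
Compound 2, `CCN(CC)CCCCn1c(N)c(-c2nc3ccccc3n2C)c2nc(C#N)c(C#N)nc21`, gives 3160 nM in this assay.
Compound 3, `CN(C)CCn1c(N)c(-c2nc3cc(Cl)ccc3[nH]2)c2nc(C#N)c(C#N)nc21`, reaches only a limit of the assay in this assay, namely > 50000 nM.

Compounds 1 and 2 share one core and differ in a single place: diethylamino in place of dimethylamino on a saturated chain carbon, four bonds along the chain from an aromatic nitrogen. This change made a step of a 1.2-fold lower number from compound 1 to compound 2 (0.09 log units; within the scatter), so the two values cannot be told apart.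

Compound 4, `CCN(CC)CCn1c(N)c(-c2nc3cc(Cl)ccc3[nH]2)c2nc(C#N)c(C#N)nc21`, is not yet measured in this assay. It differs from compound 3 in a single place: diethylamino in place of dimethylamino on a saturated chain carbon, two bonds along the chain from an aromatic nitrogen. This is the same kind of change as that from compound 1 to compound 2, but the surroundings differ: there the saturated chain carbon lies four bonds along the chain from an aromatic nitrogen, here two bonds along the chain from an aromatic nitrogen. How the core of compound 3 differs from the core of compound 1 is not broken down here.

Compound 3 sits at the limit of > 50000 nM in this assay, at which 1 of the 3 values shown sits, so no number is available to set a step against. The earlier pair, however, showed that the change hardly moved the value, since a 1.2-fold lower number from compound 1 to compound 2 (0.09 log units; within the scatter) lies within the scatter. For compound 4 the step that the limit leaves unreadable from compound 3 to compound 4 is therefore expected. Compound 4 is expected to give about 60000 nM, most likely between 30000 nM and 150000 nM, and it is quite possible that again only a limit of the assay is reported.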

Compound 4, half-maximal inhibitory concentration: > 50000 nM
Compound 4: only a limit was reported; the forecaster's own chance of this, stated with the estimate: 75%; the middle value lies beyond the limit too.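

Compound 3 and compound 4 both reach only a limit in this assay, so no step between them can be read: the limit of > 50000 nM in this assay, at which 2 of the 4 values shown sit.

The compounds shown leave open what the actual values of compound 3 and compound 4 are, and whether diethylamino in place of dimethylamino changes the value on this core as little as it does between compound 1 and compound 2.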